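The compounds below may be only part of what the source reports. "The series", "measured", "known", "first", "only" and "open" are said of these compounds alone.

In a functional assay on HL-60 cells (Homo sapiens) for cytotoxicity, read by luminescence and CellTiter-Glo, with a stated time of 3 days (on this read-out lower numbers stand for stronger inhibition and higher numbers for weaker inhibition), two compounds sharing one core have been measured. Compound 1 (`N#Cc1cc(Cl)ccc1NC(=O)c1ccc2cccnc2c1O`) gives 790 nM, and compound 2 (`O=C(Nc1ccc(C(F)(F)F)cc1)c1ccc2cccnc2c1O`) gives 680 nM. Compound 2 therefore stands level with compound 1, since the two values lie within the scatter of each other and neither can be ranked ahead. For the measured compounds named here, the pair differs in more than one place, so it offers no measured single-change step.

Compound 3 (`O=C(Nc1ccc(Cl)cc1)c1ccc2cccnc2c1O`) has not yet been measured. It departs from compound 2 in one place: chloro in place of trifluoromethyl on an aromatic carbon. This puts chloro in place of trifluoromethyl on an aromatic carbon, para to a large group.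

Going by the values given here, with no measured step of this kind to draw on, no change beyond the scatter is expected in this assay, and neither direction is favoured. This expectation rests only on the closeness of compound 1 at 790 nM and compound 2 at 680 nM, despite their different substituents. The estimated change is a 1.1-fold higher number from compound 2 to compound 3 (0.04 log units; within the scatter), a step expected to stay within the scatter. For compound 3 the estimated value is 750 nM, with an expected range of 320 nM to 1800 nM.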

Compound 3, half-maximal inhibitory concentration: 630 nM
Estimate against measurement, compound 3: 1.2-fold (0.08 log units) above, within the range that was stated.
By their numbers in this assay, from the lowest: compounds 3, 2 and 1 (each within the scatter of the next).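

In this assay, chloro in place of trifluoromethyl on an aromatic carbon, para to a large group, gives a 1.1-fold lower number from compound 2 to compound 3 (0.03 log units; within the scatter), so at this position one heavy atom in place of four makes no difference that can be told from the scatter. The series also gains its first single-change links, and hydrogen in place of cyano on an aromatic carbon gives a 1.3-fold lower number from compound 1 to compound 3 (0.10 log units; within the scatter), which likewise stays within the scatter and shows that the cyano group of the earlier compound has no readable effect on the number in this assay. Nothing measured here accounts for why these exchanges leave the value level.

The compounds shown leave open whether this position would stay equally undemanding with an amine, a carboxylic acid or a longer chain such as butoxy in place of chloro, as the groups compared there so far are only trifluoromethyl and chloro. They also leave open what a methoxy group in place of the hydroxyl of the shared core would do, as that part stays the same in all three compounds.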